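Swapping the aryl on the triazole of compound 2

The compounds below may be only part of what the source reports. "The series", "measured", "known", "first", "only" and "open" are said of these compounds alone.

Of the compounds shown here, three sharing one core have been measured in a functional assay on PC-3 cells (Homo sapiens) for inhibition, read by sulforhodamine B assay, with a stated time of 48 h, tested at 50 uM; on this read-out lower numbers stand for less inhibition of growth and higher numbers for more inhibition of growth at the one concentration tested. Compound 1 `COc1cc2c(cc1CC=C(C)C)/C(=N/NC(N)=O)C[C@@H](c1ccc(O)cc1)O2` gives 67%. Compound 2 `COc1ccc([C@@H]2C/C(=N/OCc3cn(-c4ccc(Cl)cc4C)nn3)c3cc(CC=C(C)C)c(OC)cc3O2)cc1` gives 49%. Compound 3 `COc1cc2c(cc1CC=C(C)C)C(=O)C[C@@H](c1ccc(Oc3cccc([N+](=O)[O-])c3)cc1)O2` gives 21%. Compound 2 thus stands second highest of the three numbers in this assay: its nearest neighbour is compound 1, whose number lies higher by a gap beyond the scatter, and furthest from it is compound 3, whose number lies lower, likewise by a gap beyond the scatter. Among the compounds with values here, none of the three differs from another in one place only, so no single step between measured compounds is available.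

The account now turns to compound 4 `COc1ccc([C@@H]2C/C(=N/OCc3cn(-c4ccc(C#N)cc4)nn3)c3cc(CC=C(C)C)c(OC)cc3O2)cc1`, which has not yet been measured in this assay. It differs from compound 2 in one place: 4-cyanophenyl in place of 4-chloro-2-methylphenyl on an aromatic nitrogen. The 4-chloro-2-methylphenyl leaves and 4-cyanophenyl enters, on an aromatic nitrogen of a five-membered aromatic ring with 3 nitrogen.

Within the data shown here, with no measured step of this kind to draw on, the expected step in this assay a number 4 percentage points lower from compound 2 to compound 4 (within the scatter) is a small one, if any, and not clearly beyond the scatter in either direction. Compound 4 is estimated to give 45%, within a range from 25% to 65%.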

Compound 4, percent growth inhibition at one concentration: 50%
The estimate for compound 4 lay 5 percentage points below the measured number, within the range that was stated.
By their numbers in this assay, from the lowest: compound 3; then compounds 2 and 4 (each within the scatter of the next); then compound 1.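

Within the data shown here, this is the first step in the set that changes one place only, and in this assay it reads a number 1 percentage points higher from compound 2 to compound 4 (within the scatter) for 4-cyanophenyl in place of 4-chloro-2-methylphenyl on an aromatic nitrogen. The earlier compounds shown here could not show this, since they differ from one another in more than one place. It shows that this aromatic nitrogen of the five-membered aromatic ring with 3 nitrogen can carry either aryl group with no difference beyond the scatter, although the entering group has a triple bond and a hydrogen-bond acceptor that the leaving group lacks. No measurement shown here bears on why the two compounds read alike.

What the compounds leave open is whether this holds for other kinds of group at the same place, such as a phenyl ring bearing an amine or a carboxylic acid, or a longer alkyl chain in place of the aryl. The step also does not link to compound 1, which differs from compound 2 and compound 4 in more than one place, so the number of compound 1 at 67% cannot be traced to any single change.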